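Working notes: 4-chlorophenyl to 4-methoxyphenyl

This account rests on a few compounds, and the source may have more. Where it says the series, first, only, none or still open, it means among the compounds named here.

Measured in a functional assay on A549 cells (Homo sapiens) for antiproliferative activity, read by MTT assay, with a stated time of 48 h; a lower number here means a stronger inhibitor, a higher number a weaker inhibitor:
- compound 1 `O=C(/C=C/c1ccc(C(F)(F)F)cc1)Nc1nnc(-c2ccc(Br)cc2)s1`: 4.68 ug/mL
- compound 2 `O=C(/C=C/c1ccc(C(F)(F)F)cc1)Nc1nnc(-c2ccc(Cl)cc2)s1`: 3.09 ug/mL

Compound 2 cannot be separated from compound 1 on these numbers, since the gap between them lies within the scatter. The next compound is compound 3 `COc1ccc(-c2nnc(NC(=O)/C=C/c3ccc(C(F)(F)F)cc3)s2)cc1`, and the change is methoxy in place of chloro on an aromatic carbon, para to a large group. Among the measured compounds shown here, only one measured step bears on this place, a 1.5-fold lower number from compound 1 to compound 2 (0.18 log units; within the scatter), chloro in place of bromo on an aromatic carbon. For the measured compounds named here, that step stays within the scatter, but it exchanges one halogen for another, and no measured compound carries methoxy. No step beyond the scatter is therefore expected in this assay, though the range stays wide. For compound 3 the estimated value is 4 ug/mL, with an expected range from 1.5 ug/mL to 11 ug/mL. The expected change is a 1.3-fold higher number from compound 2 to compound 3 (0.11 log units; within the scatter).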

Compound 3, half-maximal inhibitory concentration: 0.69 ug/mL
For compound 3 the middle estimate is 5.8-fold (0.76 log units) above the measured one, and the stated range ends above it.
By their numbers in this assay, from the lowest: compound 3; then compounds 2 and 1 (each within the scatter of the next).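

With a 4.5-fold lower number from compound 2 to compound 3 (0.65 log units; beyond the scatter) in this assay this position shows its first step beyond the scatter, and a 6.8-fold lower number from compound 1 to compound 3 (0.83 log units; beyond the scatter) points the same way from the bromo compound. Exchanging one halogen for the other had left compound 1 and compound 2 inseparable, whereas methoxy in place of either halogen gives a modest but readable drop in the number, so the group at this place does matter in this series. Nothing available explains why methoxy differs from the two halogens.

The compounds shown leave open whether the lower number is particular to methoxy or extends to other groups at this place, such as a hydroxyl, an amine or a longer alkoxy chain. With a single non-halogen group in hand, no trend across substituents can yet be drawn.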